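Swapping methoxy for fluoro on the phenyl sulfonate ester

This account rests on a few compounds, and the source may have more. Where it says the series, first, only, none or still open, it means among the compounds named here.

Measured compounds:
compound 1 `CCCN1CCN(c2ccc(S(=O)(=O)Oc3cccc(OC)c3)cc2)C1=O` 6300 nM
compound 2 `CCCN1CCN(c2ccc(S(=O)(=O)Oc3cccc(F)c3)cc2)C1=O` 24000 nM
compound 3 `CCCN1CCN(c2ccc(S(=O)(=O)Oc3ccc(OC)cc3)cc2)C1=O` 20000 nM

These three share one core and differ only in the phenyl ring on the sulfonate oxygen. In a functional assay on MCF7 cells (Homo sapiens) for antiproliferative activity, read by sulforhodamine B assay, with a stated time of 48 h (a lower number here means a stronger inhibitor, a higher number a weaker inhibitor), compound 1 gives 6300 nM, compound 2 gives 24000 nM and compound 3 gives 20000 nM. The change fluoro in place of methoxy on an aromatic carbon made a step of a 3.8-fold higher number from compound 1 to compound 2 (0.58 log units; beyond the scatter). The cores of compound 1 and compound 3 differ as 4-methoxyphenyl in place of 3-methoxyphenyl on an oxygen, a step of a 3.2-fold higher number from compound 1 to compound 3 (0.50 log units; beyond the scatter). Compound 4 `CCCN1CCN(c2ccc(S(=O)(=O)Oc3ccc(F)cc3)cc2)C1=O` is not yet measured; it arises from compound 3 by fluoro in place of methoxy on an aromatic carbon, the same kind of change as before, but here the group sits para to a large group rather than meta to a large group. A step near the earlier one is expected, a 3.0-fold higher number from compound 3 to compound 4 (0.48 log units; beyond the scatter), resting on compound 2 with 24000 nM. Compound 4 is therefore estimated at 60000 nM, between 20000 nM and 200000 nM.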

Compound 4, half-maximal inhibitory concentration: 33000 nM
Compound 4: middle estimate off by 1.8-fold (0.26 log units), on the high side; low and high end bracket the measured number.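

Carried to the core of compound 3, fluoro in place of methoxy makes a step of a 1.7-fold higher number from compound 3 to compound 4 (0.22 log units; within the scatter), and 4-fluorophenyl in place of 3-fluorophenyl makes one of a 1.4-fold higher number from compound 2 to compound 4 (0.14 log units; within the scatter), while the two changes taken together make a 5.2-fold higher number from compound 1 to compound 4 (0.72 log units; beyond the scatter). The steps for the methoxy-to-fluoro change on the two cores cannot be told apart: the same change on two cores in this assay, a 3.8-fold higher number (0.58 log units; beyond the scatter) from compound 1 to compound 2 and a 1.7-fold higher number (0.22 log units; within the scatter) from compound 3 to compound 4, 2.3-fold (0.36 log units) apart, within the scatter of two such steps. This is compatible with the change carrying over between these cores, but two pairs cannot show that its size is the same; the step lies beyond the scatter on one core and within it on the other.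

As far as these compounds go, whether this holds for a chlorine or an amine on that ring remains open. So does its behaviour with a longer chain on the shared core.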